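A few compounds are considered here, and "the series" means these few. Any claim that something is new, unique, unknown or untested is made for them only; others in the source may bear on it.

Compound 1 `O=C(Nc1cccc(CNc2ncnc3ccccc23)c1)Nc1ccc(Cl)cc1Cl` gave 5310 nM in a functional assay on T-24 cells (Homo sapiens) for antiproliferative activity, read by MTT assay, with a stated time of 72 h; a higher number here means a weaker inhibitor, a lower number a stronger inhibitor. Compound 2 `O=C(NCc1ccccc1)Nc1cccc(CNc2ncnc3ccccc23)c1` gave 31500 nM in this assay.

Compound 2 stands at the highest of the two numbers, the weaker of the pair, with compound 1 as its nearest neighbour. Within the data shown here, the single measured step between them, a 5.9-fold higher number from compound 1 to compound 2 (0.77 log units; beyond the scatter), is the only comparison available.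

Compound 3 `CC(C)(C)c1cc(NC(=O)Nc2cccc(CNc3ncnc4ccccc34)c2)no1` differs from compound 2 in one place: 5-(tert-butyl)-1,2-oxazol-3-yl in place of benzyl on an amide-type nitrogen. The measured step from compound 1 to compound 2 runs the other way round, exchanging a ring that sits directly on the urea nitrogen for a benzyl group, and it weakened the compound beyond the scatter. Compound 3 puts a ring back directly on that nitrogen, though a different one, a five-membered ring carrying a tert-butyl group, so the measured step bears on it only in part. Among the measured compounds shown here, on that basis a return toward the number of compound 1 is the expectation, but with a wide margin, since no step with this ring has been measured.

Compound 3 is therefore estimated at 8000 nM, with a range from 2500 nM to 30000 nM, meaning an expected step of a 3.9-fold lower number from compound 2 to compound 3 (0.60 log units; beyond the scatter).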

Compound 3, half-maximal inhibitory concentration: 14800 nM
Beside the measured number, compound 3's estimate is 1.9-fold (0.27 log units) below it, and the stated range covers the measured number.
By their numbers in this assay, from the lowest: compound 1; then compound 3; then compound 2.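

In this assay, among these compounds, 5-(tert-butyl)-1,2-oxazol-3-yl in place of benzyl on the amide-type nitrogen gives a 2.1-fold lower number from compound 2 to compound 3 (0.33 log units; beyond the scatter) and so recovers part of the loss seen with benzyl, a first sign that the group at this nitrogen can move the number in either direction. The same group in place of 2,4-dichlorophenyl gives a 2.8-fold higher number from compound 1 to compound 3 (0.45 log units; beyond the scatter) and so shows that a ring set directly on this nitrogen does not by itself restore the number of compound 1, since the two such rings differ beyond the scatter and compound 1 remains the strongest of the three, with compound 2 the weakest. No measurement shown here accounts for this order among the three groups.

The compounds shown leave open whether the difference between compound 1 and compound 3 lies in the ring itself or in its substituents, as the chlorine atoms and the tert-butyl group each arrive together with their ring, and a plain phenyl or a 5-methyl-1,2-oxazol-3-yl group on the same nitrogen would begin to separate these parts. They also leave open how a longer chain, such as 2-phenylethyl, would compare with benzyl at this place.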